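The source may report more compounds than this note shows. Statements on the series, on what has been measured and on what is new or still open speak of the compounds shown alone.

Compound 1 `COc1ccc(-c2nc(SC)n(C)c(=O)c2C#N)cc1`: 48 ug/mL
Compound 2 `CCOC(=O)c1cnn(-c2nc(-c3ccc(N(C)C)cc3)c(C#N)c(=O)n2C)c1N`: 119 ug/mL

Of the compounds shown here, two have so far been measured in a functional assay, with a stated time of 10 min; a lower number here means a stronger inhibitor, a higher number a weaker inhibitor. Compound 1 gives 48 ug/mL, while compound 2 gives 119 ug/mL, the higher of the two numbers; the gap between them lies beyond the usual scatter, so compound 2 is the weaker inhibitor of this pair. Compound 3 `CCOC(=O)c1cnn(-c2nc(-c3cccc(O)c3O)c(C#N)c(=O)n2C)c1N` has not yet been measured. It differs from compound 2 in one place: 2,3-dihydroxyphenyl in place of 4-(dimethylamino)phenyl on an aromatic carbon. Among the measured compounds shown here, no measured pair in this set shows what such an exchange does to the read-out, so there is no step to lean on. Compound 2 already carries the highest number, and nothing in the data points a direction for the change, in either sense. The expected step is therefore a 1.1-fold lower number from compound 2 to compound 3 (0.03 log units; within the scatter), which is to say none beyond the scatter, with the range kept deliberately wide to allow for a move either way. In this assay compound 3 is estimated at 110 ug/mL, most likely falling between 40 ug/mL and 300 ug/mL.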

Compound 3, half-maximal inhibitory concentration: 53 ug/mL
Estimate against measurement, compound 3: 2.1-fold (0.32 log units) above; low and high end bracket the measured number.
By their numbers in this assay, from the lowest: compounds 1 and 3 (each within the scatter of the next); then compound 2.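

In this assay, the aromatic carbon next to the ring nitrogen and ortho to the cyano group proves sensitive to the aryl group it carries: 2,3-dihydroxyphenyl in place of 4-(dimethylamino)phenyl gives a 2.2-fold lower number from compound 2 to compound 3 (0.35 log units; beyond the scatter), a modest step beyond the scatter, with the rest of the molecule unchanged. Among the compounds shown here, this is the first direct reading of a change at this position, and it favours the dihydroxylated ring over the dimethylamino-substituted one, although this single pair changes several things at once: the dimethylamino group leaves, and the hydroxyl groups enter. No independent evidence is available to explain the step.

The compounds shown leave open how much of the step belongs to losing the dimethylamino group and how much to gaining the hydroxyl groups, a question that an unsubstituted phenyl ring or a phenyl ring carrying a single hydroxyl group would help to separate. They also leave open whether a carboxylic acid on the phenyl ring would give a number lower than that of compound 3, or whether the trend holds beyond this one pair.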